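A few compounds are considered here, and "the series" means these few. Any claim that something is new, unique, unknown or untested is made for them only; others in the source may bear on it.

Compound 1 `CCS[C@@H]1[C@H](SCC)[C@@H](Cn2cc(-c3cccs3)nn2)O[C@H]1n1ccc(=O)[nH]c1=O` gives 86500 nM in a functional assay on LAC cells (Homo sapiens) for cytotoxicity, read by MTT assay, with a stated time of 72 h; a higher number here means that more compound is needed for the effect, a lower number that less compound is needed. Compound 2 `CCS[C@@H]1[C@H](SCC)[C@@H](Cn2cc(-c3ccccc3C(F)(F)F)nn2)O[C@H]1n1cc(C)c(=O)[nH]c1=O` gives 50600 nM in this assay. Compound 3 `CCS[C@@H]1[C@H](SCC)[C@@H](Cn2cc(-c3ccc(C)cc3)nn2)O[C@H]1n1cc(C)c(=O)[nH]c1=O` reaches only the limit of >= 100000 nM in this assay, so no number is known for it.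

Compound 3 thus stands at the edge of these values, at the limit (the limit of >= 100000 nM in this assay, at which 1 of the 3 values shown sits). Among the measured compounds shown here, the one measured step onto it, an at least 1.9-fold higher number from compound 2 to compound 3 (0.29 log units; that floor lies within the scatter), has a floor that lies within the scatter. Compound 4 `CCS[C@@H]1[C@H](SCC)[C@@H](Cn2cc(-c3cccs3)nn2)O[C@H]1n1cc(C)c(=O)[nH]c1=O` carries the change (thiophen-2-yl in place of 4-methylphenyl on an aromatic carbon). For the measured compounds named here, no measured step covers this exchange directly; compound 1 carries the same thiophen-2-yl group and gives a number, while compound 4 shares the core of compound 3. Compound 4 is therefore expected to give about 90000 nM, between 45000 nM and 200000 nM, a step of an at least 1.1-fold lower number from compound 3 to compound 4 (0.04 log units; that floor lies within the scatter) that may well stay at the limit.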

Compound 4, half-maximal effective concentration: >= 100000 nM
Compound 4 was reported as a limit; the forecaster's own chance of this, stated with the estimate: 45%; middle value at least 1.1-fold (0.04 log units) away from the limit.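

In this assay compound 4 reaches only a limit, >= 100000 nM, and gives no number. Thiophen-2-yl in place of 2-(trifluoromethyl)phenyl gives an at least 1.9-fold higher number from compound 2 to compound 4 (0.29 log units; that floor lies within the scatter), and methyl in place of hydrogen gives an at least 1.1-fold higher number from compound 1 to compound 4 (0.06 log units; that floor lies within the scatter), so neither change is shown to exceed the usual scatter. The step between the two limits cannot be read, which leaves thiophen-2-yl and 4-methylphenyl unseparated, and a second compound now stands at the edge of the values: the limit of >= 100000 nM in this assay, at which 2 of the 4 values shown sit.

As far as these compounds go, whether compound 3 and compound 4 differ at all stays open. Also open, from the compounds shown here alone, is whether an amine or a carboxylic acid at this place on the five-membered aromatic ring with 3 nitrogen would give a readable number.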